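A Longer Chain on a Compound at the Limit

A few compounds are considered here, and "the series" means these few. Any claim that something is new, unique, unknown or untested is made for them only; others in the source may bear on it.

In a physicochemical assay for solubility, read by HPLC, at pH 7.4 (a higher number here means a more soluble compound, a lower number a less soluble compound), compound 1 `COc1cc2[nH]c(C)c(C)c(=O)c2cc1Cl` gives 5000 nM as its reading. Compound 2 `COc1cc2[nH]c(C)c(C(C)C)c(=O)c2cc1Cl` gives > 20000 nM and this is a limit of the assay, not a number. For the measured compounds named here, the only measured step is an at least 4.0-fold higher number from compound 1 to compound 2 (0.60 log units; beyond the scatter) and it ends at that limit, so its full size stays open. In compound 3 `C=C(CCCCC)c1c(C)[nH]c2cc(OC)c(Cl)cc2c1=O` a group of 7 heavy atoms replaces isopropyl on the same aromatic carbon, with a group of 7 heavy atoms (7 carbon; no ring) in place of a group of 3 heavy atoms (3 carbon; no ring), on an aromatic carbon as the counted difference. With only an at least 4.0-fold higher number from compound 1 to compound 2 (0.60 log units; beyond the scatter) to go on, and that from a smaller swap, a modest fall in this assay is expected, though compound 3 may also return only a limit. The estimate means an at least 3.3-fold lower number from compound 2 to compound 3 (0.52 log units; beyond the scatter) as the expected change. For compound 3 the expected value is 6000 nM with an estimated range from 1000 nM to 20000 nM as its upper end.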

Compound 3, solubility: 2000 nM
For compound 3 the middle estimate is 3.0-fold (0.48 log units) above the measured one, within the range that was stated.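

In this assay the position that rose with isopropyl in place of methyl turns back with the longer group, an at least 10-fold lower number from compound 2 to compound 3 (1.00 log units; beyond the scatter). Compound 2 is a limit and not a number, and the full size of that step stays open because of it: the limit of > 20000 nM in this assay, at which 1 of the 3 values shown sits.

The fall also carries past the starting point, a 2.5-fold lower number from compound 1 to compound 3 (0.40 log units; beyond the scatter), so across these three compounds the reading does not move in one direction with the heavy-atom count of the group on this aromatic carbon.

The compounds shown leave open whether the fall goes with the length of the chain or with its double bond, a question that a saturated chain of 7 carbon would separate. They also leave open where between isopropyl and this group the reading turns, which a butyl group could begin to place.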